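This account rests on a few compounds, and the source may have more. Where it says the series, first, only, none or still open, it means among the compounds named here.

Compound 1, with structure `O=C1[C@@H](NS(=O)(=O)c2ccc(-c3ccon3)s2)CCN1Cc1cc2c[nH]ccc-2n1`, has the lowest number in this small set: in an assay on isolated protein for inhibition of coagulation factor X (Oryctolagus cuniculus), tested at 1 uM (on this read-out higher numbers stand for more inhibition at the one concentration tested (going by the name of the read-out) and lower numbers for less inhibition), compound 1 gives 17%, the lowest of the three numbers. Its nearest neighbour is compound 3, structure `O=C1[C@@H](NS(=O)(=O)c2ccc(-c3ccon3)s2)CCN1CCNc1ccncc1`, which in this assay gives 22%; the step of a number 5 percentage points higher from compound 1 to compound 3 (within the scatter) lies within the scatter. Compound 2, structure `O=C1[C@@H](NS(=O)(=O)c2ccc(-c3ccon3)s2)CCN1Cc1cc2cc[nH]cc-2n1`, gives 49% in this assay, and the step of a number 32 percentage points higher from compound 1 to compound 2 (beyond the scatter) is the one clear movement among the measured compounds, with a number 27 percentage points lower from compound 2 to compound 3 (beyond the scatter) running the other way.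

Compound 4, structure `O=C1[C@@H](NS(=O)(=O)c2cc3ccnc(Cl)c3s2)CCN1Cc1cc2c[nH]ccc-2n1`, differs from compound 1 at the sulfonyl sulfur: a group of 10 heavy atoms (7 carbon, 1 nitrogen, 1 sulfur, 1 chlorine; one five-membered aromatic ring with 1 hetero atom, one six-membered aromatic ring with 1 hetero atom) in place of a group of 10 heavy atoms (7 carbon, 1 nitrogen, 1 oxygen, 1 sulfur; one five-membered aromatic ring with 1 hetero atom, one five-membered aromatic ring with 2 hetero atoms), on a sulfonyl sulfur. Going by the values given here, none of the measured steps touches this position; all three vary the group on the saturated chain carbon bound to the amide-type nitrogen in the ring. The data therefore give no direct guide to the size or direction of this step, and the expectation rests only on the low starting value of compound 1.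

Compound 4 is estimated at 35% in this assay, within a range of 8% to 70%. This means an expected step of a number 18 percentage points higher from compound 1 to compound 4 (beyond the scatter), which is uncertain in direction.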

Compound 4, a percentage reported as inhibition, at one concentration (the size of the read-out at that concentration, not a potency): 25%
Estimate against measurement, compound 4: 10 percentage points above, within the range that was stated.
By their numbers in this assay, from the lowest: compounds 1, 3 and 4 (each within the scatter of the next); then compound 2.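

Going by these compounds alone, compound 4 gives the first reading at the sulfonyl sulfur, whose other neighbour is the sulfonamide nitrogen. In this assay the step of a number 8 percentage points higher from compound 1 to compound 4 (within the scatter) shows that, on the core of compound 1, the 5-(1,2-oxazol-3-yl)thiophen-2-yl group can give way to a chlorine-bearing group with a six-membered aromatic ring without a distinct change in the read-out. At this level of inhibition the two groups cannot be told apart, and nothing measured here offers an explanation for that result.

The compounds shown leave open whether the same exchange would also read within the scatter on the core of compound 2, where the starting number is higher. They also leave open what the chlorine contributes, as a version of the entering group with a methyl or methoxy group in its place would show.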